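The source may hold more compounds than are shown below. What is called first, only, known or untested is meant among the compounds shown, and "the series" means these compounds.

In a functional assay on brain (Rattus norvegicus, strain Wistar) for inhibition (a lower number here means a stronger inhibitor, a higher number a weaker inhibitor), compound 1 `COc1ccc(/C=C2\COc3cc(OC)ccc3C2=O)cc1` gives > 100000 nM as a limit of the assay, not a number. Compound 2 `COc1ccc2c(c1)OC/C(=C\c1ccccc1OC)C2=O` gives > 100000 nM as well, again only a limit. For the measured compounds named here, compound 3 `CCOc1ccc2c(c1)OC/C(=C\c1ccc(O)c(O)c1)C2=O` gives 11900 nM and is the only one of the three with a number so far. Compound 4 `CCCCOc1ccc2c(c1)OC/C(=C\c1ccc(O)c(O)c1)C2=O` carries butoxy in place of the ethoxy of compound 3, a change counted as ethyl in place of hydrogen on a saturated chain carbon, two bonds along the chain from an oxygen on an aromatic ring on the shared core. Going by the values given here, no measured step covers this change. The expectation is a modest shift in this assay toward stronger inhibition, estimated as a 1.5-fold lower number from compound 3 to compound 4 (0.17 log units; within the scatter) and little beyond the scatter. For compound 4 the estimated value is 8000 nM with an expected range from 2500 nM to 30000 nM in this read-out.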

Compound 4, half-maximal inhibitory concentration: 11000 nM
Beside the measured number, compound 4's estimate is 1.4-fold (0.14 log units) below it, and the stated range covers the measured number.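

In this assay, going from ethoxy to butoxy gives a 1.1-fold lower number from compound 3 to compound 4 (0.03 log units; within the scatter), so an added ethyl on a saturated chain carbon, two bonds along the chain from an oxygen on an aromatic ring, is tolerated with no shift beyond the scatter. The earlier compounds shown here offered no step at this position. Compounds 1 and 2 provide only limits of the assay, not numbers: the limit of > 100000 nM in this assay, at which 2 of the 4 values shown sit.

As far as these compounds go, whether a longer chain would leave the value equally flat remains open. So does the effect of an amine or a carboxylic acid at the chain end.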